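The compounds below may be only part of what the source reports. "The series", "measured", "known", "first", "only" and "open" are said of these compounds alone.

Measured so far in a functional assay on CHO cells for agonist activity at Free fatty acid receptor 1 (Homo sapiens), read by FLIPR and calcium flux; on this read-out lower numbers stand for an effect already at smaller amounts and higher numbers for an effect only at larger amounts of compound:
compound 1 `CCCOc1cc(C)c(-c2cccc(COc3ccc(S(=O)(=O)CC(=O)O)cc3)c2)c(C)c1` — 69.2 nM
compound 2 `Cc1nc(-c2ccccc2)sc1COc1ccc(S(=O)(=O)CC(=O)O)cc1` — 331 nM

Compound 2 gives the higher of the two numbers in this assay, its value sitting well apart from that of compound 1, beyond the scatter. Among the measured compounds shown here, no step between these two is worked out; only their values are compared here.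

Compound 3 `Cc1nc(-c2ccc(F)cc2)sc1COc1ccc(S(=O)(=O)CC(=O)O)cc1` differs from compound 2 by fluoro in place of hydrogen on an aromatic carbon. With no measured step of this kind in the series, the expectation rests on a single point, and the change is small. The step of a 1.3-fold lower number from compound 2 to compound 3 (0.12 log units; within the scatter) is expected to stay within the scatter, with at most a slight lowering. Compound 3 is therefore estimated at 250 nM, in a range of 100 nM to 700 nM.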

Compound 3, half-maximal effective concentration: 191 nM
Compound 3: the middle estimate sits 1.3-fold (0.12 log units) above what was measured; low and high end bracket the measured number.
By their numbers in this assay, from the lowest: compound 1; then compounds 3 and 2 (each within the scatter of the next).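

In this assay, among the compounds shown here, this is the first step that differs in one place: phenyl to 4-fluorophenyl, para to a large group (a 1.7-fold lower number from compound 2 to compound 3 (0.24 log units; within the scatter)). The change of hydrogen to fluoro at this position therefore leaves the number within the scatter, so the two groups are not told apart here. No data at hand speak to the reason for this result.

As far as these compounds go, whether methoxy, trifluoromethyl or a chlorine atom at this position would move the number beyond the scatter stays open. So does the effect of fluoro at other places on this aromatic ring.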